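Benzyloxy analogue of compound 3 in the aryl ether series

This account rests on a few compounds, and the source may have more. Where it says the series, first, only, none or still open, it means among the compounds named here.

Measured so far:
compound 1 `CCOc1cccc(-c2ccc([C@H]3S[C@@H](C)C(=O)Nc4c3c(C)nn4-c3ccccc3C)cc2)c1`: 3500 nM
compound 2 `COC(=O)c1ccc(-c2ccc([C@H]3S[C@@H](C)C(=O)Nc4c3c(C)nn4-c3ccccc3C)cc2)cc1`: "not active" (no number reported)
compound 3 `COc1cccc(Oc2ccc([C@H]3S[C@@H](C)C(=O)Nc4c3c(C)nn4-c3ccccc3C)cc2)c1`: 1700 nM

In an assay on isolated protein for agonist activity at Bile acid receptor (Homo sapiens), read by AlphaScreen, with a stated time of 30 min (a higher number here means that more compound is needed for the effect, a lower number that less compound is needed), compound 3 gives 1700 nM, the lowest of the two numbers reported; compound 1 gives 3500 nM and compound 2 is reported as "not active" (no number reported). Among the compounds with values here, the only measured step, a 2.1-fold lower number from compound 1 to compound 3 (0.31 log units; beyond the scatter), changes both the ring substituent and the link to the shared core at once. Compound 4 `Cc1ccccc1-n1nc(C)c2c1NC(=O)[C@H](C)S[C@@H]2c1ccc(OCc2ccccc2)cc1` differs from compound 3 in one place: benzyl in place of 3-methoxyphenyl on an oxygen on an aromatic ring. Within the data shown here, no measured step shows an aromatic ring moved one bond further from the ether oxygen, so no direction is well supported; the one step available was modest, and a step of similar size is expected here, if any beyond the scatter. For compound 4 an expected value of 2500 nM is estimated, between 800 nM and 8000 nM, meaning a 1.5-fold higher number from compound 3 to compound 4 (0.17 log units; within the scatter).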

Compound 4, half-maximal effective concentration: "not active" (no number reported)
For compound 4 the study gives words and no number; the estimate stays without a comparison.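

In this assay, within the data shown here, compound 4 is reported only as "not active", so no step from compound 3 to compound 4 can be read. The compounds shown leave open whether any benzyloxy analogue of compound 3 would give a number. No evidence bears on this result.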